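Iodo to trifluoromethyl at the end of the halogen series

The compounds below may be only part of what the source reports. "The series", "measured", "known", "first", "only" and "open" are said of these compounds alone.

In a functional assay on HepG2 cells (Homo sapiens) for inhibition, read by MTT assay (a higher number here means a weaker inhibitor, a lower number a stronger inhibitor), compound 1 `COc1cc2ncnc(Nc3ccc(NC(=O)c4ccc(F)cc4)cc3)c2cc1OC` gives 15000 nM, compound 2 `COc1cc2ncnc(Nc3ccc(NC(=O)c4ccc(Br)cc4)cc3)c2cc1OC` gives 35000 nM and compound 3 `COc1cc2ncnc(Nc3ccc(NC(=O)c4ccc(I)cc4)cc3)c2cc1OC` gives 40000 nM. Compound 3 sits at the upper end of these numbers, but not clear of every neighbour: the iodo for bromo exchange gives a 1.1-fold higher number from compound 2 to compound 3 (0.06 log units; within the scatter), while the iodo for fluoro exchange gives a 2.7-fold higher number from compound 1 to compound 3 (0.43 log units; beyond the scatter). The bromo for fluoro exchange gives a 2.3-fold higher number from compound 1 to compound 2 (0.37 log units; beyond the scatter).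

Compound 4 `COc1cc2ncnc(Nc3ccc(NC(=O)c4ccc(C(F)(F)F)cc4)cc3)c2cc1OC` carries the next change, trifluoromethyl in place of iodo on an aromatic carbon, para to a large group. Going by the values given here, no measured step brings in trifluoromethyl, so the halogen exchanges at this place bear on it only indirectly. The largest of them is modest, and the smallest stays within the scatter.

In this assay the expected step is small and slightly downward, a 1.4-fold lower number from compound 3 to compound 4 (0.15 log units; within the scatter), with no firm direction beyond the scatter. The estimated value for compound 4 is 28000 nM, with an expected range of 13000 nM to 60000 nM.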

Compound 4, half-maximal inhibitory concentration: > 100000 nM
Compound 4 gave a limit, no number; the forecaster's own chance of this, stated with the estimate: 10%; at least 3.5-fold (0.55 log units) between middle value and limit.
By their numbers in this assay, from the lowest: compound 1; then compounds 2 and 3 (each within the scatter of the next). At a limit, above all of these: compound 4.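

In this assay, compound 4 reads only as a limit of the assay, not as a number: the limit of > 100000 nM in this assay, at which 1 of the 4 values shown sits.

Trifluoromethyl is the first group at this place, on an aromatic carbon para to a large group, to stand clear of both the bromo and the iodo compound, which remain within the scatter of each other: an at least 2.8-fold higher number from compound 2 to compound 4 (0.45 log units; beyond the scatter) and an at least 2.5-fold higher number from compound 3 to compound 4 (0.39 log units; beyond the scatter). Against the fluoro compound the step reads an at least 6.6-fold higher number from compound 1 to compound 4 (0.82 log units; beyond the scatter), and all three steps are lower bounds set by the limit, so their full size stays unknown.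

On these data alone, it remains open how far compound 4 lies past its limit. As far as these compounds go, it also remains open whether an amine, a carboxylic acid or a methoxy group at this place would fall below the number of compound 1 or climb towards that of compound 4.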